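Working notes: from compound 2 to compound 3

The source may hold more compounds than are shown below. What is called first, only, known or untested is meant among the compounds shown, and "the series" means these compounds.

Measured so far in a toxicity assay on microsomes from liver (Homo sapiens) for metabolic stability, read by LC-MS, using NADPH, tested at 1 uM; a higher number here means faster removal of the compound, a lower number slower removal:
Compound 1 `CCOc1ncc(-c2nc(C(F)(F)F)sc2N2CCN(C(=O)Cn3cnc4ccccc43)[C@H](C)C2)cn1`: 662 mL.min-1.g-1
Compound 2 `CCOc1ncc(-c2nc(C(F)(F)F)sc2N2CCN(C(=O)Cn3nccc3C)[C@H](C)C2)cn1`: 65 mL.min-1.g-1

Among the measured compounds shown here, of these two numbers, compound 2 holds the lower, and compound 1 is its only neighbour, beyond the scatter. Compound 3 `CCOc1ncc(-c2nc(C(F)(F)F)sc2N2CCN(C(=O)Cn3nc(C)cc3C)[C@H](C)C2)cn1` is still to be measured in this assay. It differs from compound 2 by methyl in place of hydrogen on an aromatic carbon. In words, this is methyl in place of hydrogen on an aromatic carbon, turning 5-methyl-1H-pyrazol-1-yl into 3,5-dimethyl-1H-pyrazol-1-yl.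

For the measured compounds named here, only one measured step is available: a 10-fold lower number from compound 1 to compound 2 (1.01 log units; beyond the scatter). It is large, but it exchanges 1H-benzimidazol-1-yl for 5-methyl-1H-pyrazol-1-yl, which is a different change from the one at hand. Going by the values given here, it bears on the new change only loosely, and no measured pair isolates a single added methyl. The data therefore give no firm direction, and no shift beyond the scatter is expected. The expected step is a 1.2-fold higher number from compound 2 to compound 3 (0.09 log units; within the scatter). For compound 3 the estimated value is 80 mL.min-1.g-1, with an expected range from 35 mL.min-1.g-1 to 190 mL.min-1.g-1.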

Compound 3, intrinsic clearance in microsomes: 184 mL.min-1.g-1
Estimate against measurement, compound 3: 2.3-fold (0.36 log units) below; the measured number falls inside the stated range.
By their numbers in this assay, from the lowest: compound 2; then compound 3; then compound 1.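

In this assay, among the compounds shown here, the exchange of 5-methyl-1H-pyrazol-1-yl for 3,5-dimethyl-1H-pyrazol-1-yl gives a 2.8-fold higher number from compound 2 to compound 3 (0.45 log units; beyond the scatter) and is the first measured step that isolates a single added methyl, showing that this aromatic carbon of the pyrazole is not a neutral place: one added heavy atom moves the number beyond the scatter, and upward. The 3,5-dimethyl-1H-pyrazol-1-yl group still stands clear of 1H-benzimidazol-1-yl, with a 3.6-fold lower number from compound 1 to compound 3 (0.56 log units; beyond the scatter) as the step, so among these three compounds both pyrazoles give lower numbers than the benzimidazole, while the lowest number remains with the 5-methyl-1H-pyrazol-1-yl group alone. No measurement on hand accounts for the rise seen with the added methyl.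

Open, on these data alone, is whether a methoxy group, a nitrile or an ethyl group on the same aromatic carbon would shift the number in the same direction as methyl, or by a similar amount. Also open, as far as these compounds go, is where the plain 1H-pyrazol-1-yl group, carrying neither methyl, would fall relative to the two methylated pyrazoles, which would show whether the methyl at the other ring carbon contributes to the low number of the series.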